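Acetoxymethyl in place of vinyl near the assay limit

A few compounds are considered here, and "the series" means these few. Any claim that something is new, unique, unknown or untested is made for them only; others in the source may bear on it.

Compound 2 `C=CCNC1CCCc2onc(O)c21` gives > 1000000 nM in a functional assay with Mus musculus as the target (on this read-out higher numbers stand for weaker inhibition and lower numbers for stronger inhibition), which is a limit and not a number. It stands at the limit of > 1000000 nM in this assay, at which 1 of the 2 values shown sits. Among the compounds with values here, compound 1 `CCNC1CCCc2onc(O)c21` is the only member with a true number, at 391000 nM in this assay.

Compound 3 `CC(=O)OCCNC1CCCc2onc(O)c21` carries acetoxymethyl in place of vinyl on a saturated chain carbon bound to an amine nitrogen, on the shared core: acetoxymethyl in place of vinyl on a saturated chain carbon bound to an amine nitrogen.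

Within the data shown here, one measured step bears on this change: an at least 2.5-fold higher number from compound 1 to compound 2 (0.40 log units; beyond the scatter). It runs toward weaker inhibition, though it concerns a different group and its true size is hidden by the limit. Among the measured compounds shown here, no measured step tests acetoxymethyl itself. With that single step as the guide, compound 3 is expected to stay close to the limit of compound 2 in this assay, with no recovery to the level of compound 1 assumed. The estimated step is a number no higher from compound 2 to compound 3 (the limit leaves the size open), and no move beyond the scatter is expected. For compound 3 the estimate is 1000000 nM, with an expected range of 300000 nM to 3000000 nM.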

Compound 3, half-maximal inhibitory concentration: > 1000000 nM
Compound 3 gave a limit, no number; the forecaster's own chance of this, stated with the estimate: 65%; the middle value sits exactly at the limit.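

In this assay the series now shows an at least 2.5-fold higher number from compound 1 to compound 3 (0.40 log units; beyond the scatter), so acetoxy in place of hydrogen on a saturated chain carbon, two bonds along the chain from an amine nitrogen, is a second change that gives a move beyond the scatter toward weaker inhibition. The step from vinyl to acetoxymethyl cannot be read, as both values are limits and not numbers, so these two groups cannot be placed relative to each other. The read-out therefore gives no resolution for this change, and the only true number in the series remains that of compound 1: the limit of > 1000000 nM in this assay, at which 2 of the 3 values shown sit.

From the compounds shown here alone, how far compound 2 and compound 3 lie past the limit remains open, and so does whether their true values differ at all. Going by these compounds, it is also open whether any other group at this place, such as a hydroxyl, a carboxylic acid or a longer chain, would return a true number in this read-out, and whether that number would lie on the stronger side of compound 1.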